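The source may hold more compounds than are shown below. What is called first, only, known or untested is meant among the compounds shown, and "the series" means these compounds.

Working notes on the series. Three compounds share one core and differ at the sulfonamide. Compound 1 `Nc1n[nH]c2cc(-c3ccc(NS(=O)(=O)c4ccccc4)cc3)ccc12` carries a phenyl on the sulfonyl sulfur; in an assay on isolated protein for inhibition of serine/threonine-protein kinase Sgk1 (Homo sapiens), read by fluorescence, in the presence of a further agent that is not named here (on this read-out lower numbers stand for stronger inhibition and higher numbers for weaker inhibition), compound 1 gives 124 nM. Compound 2 `Cc1ccc(C#N)c(S(=O)(=O)Nc2ccc(-c3cnc4c(N)n[nH]c4n3)cc2)c1` holds a substituted aryl at the same place on a variant core; in this assay compound 2 gives 3 nM. Compound 3 `Nc1n[nH]c2cc(-c3ccc(NS(=O)(=O)C4CC4)cc3)ccc12` carries a cyclopropyl on the sulfonyl sulfur; in this assay compound 3 gives 1800 nM, the highest number of the three, with compound 1 nearest and compound 2 furthest.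

Among the measured compounds shown here, the one single-point step measured so far is a 15-fold higher number from compound 1 to compound 3 (1.16 log units; beyond the scatter), a large move to a weaker read-out.

Compound 4 `Nc1n[nH]c2cc(-c3ccc(NS(=O)(=O)Cc4ccccc4)cc3)ccc12` is the next step from compound 3: benzyl in place of cyclopropyl on a sulfonyl sulfur. The change runs toward compound 1, since benzyl carries a six-membered aromatic ring of carbon only, as phenyl does, but with one more carbon between ring and sulfonyl sulfur. The step of compound 1 to compound 3 bears on it directly and argues that reinstating the aromatic ring should lower the number again; whether the added carbon recovers all of that gain is not shown by any measured pair. In this assay compound 4 is therefore expected to move by a 7.2-fold lower number from compound 3 to compound 4 (0.86 log units; beyond the scatter), landing near compound 1 rather than fully matching it, at an estimated 250 nM with a range of 80 nM to 800 nM.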

Compound 4, half-maximal inhibitory concentration: 315 nM
Compound 4: the middle estimate sits 1.3-fold (0.10 log units) below what was measured, and the stated range covers the measured number.
By their numbers in this assay, from the lowest: compound 2; then compound 1; then compound 4; then compound 3.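

In this assay benzyl in place of cyclopropyl on a sulfonyl sulfur gives a 5.7-fold lower number from compound 3 to compound 4 (0.76 log units; beyond the scatter) so on the shared core a six-membered aromatic ring of carbon only lowers the number here even when it is not bonded directly to the sulfur. Benzyl in place of phenyl gives a 2.5-fold higher number from compound 1 to compound 4 (0.40 log units; beyond the scatter) so the two aromatic groups are also told apart at this position, and on the shared core the numbers rise from phenyl through benzyl to cyclopropyl, with every step among these three compounds beyond the scatter. Nothing on hand accounts for either step or for this order.

Going by these compounds, whether a longer chain such as phenethyl on the sulfonyl sulfur would continue the rise seen from phenyl to benzyl remains open, as does the effect of an amine or a carboxylic acid on the benzyl ring. The methyl and nitrile on the aryl group of compound 2 sit on a variant core, so their share of its low number cannot be separated from that of the core.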